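This account rests on a few compounds, and the source may have more. Where it says the series, first, only, none or still open, it means among the compounds named here.

Values in a functional assay on HL-60 cells (Homo sapiens) for cytotoxicity, read by WST assay, with a stated time of 48 h (a higher number here means that more compound is needed for the effect, a lower number that less compound is needed), for the measured compounds:

Compound 1 `O=C1OC[C@H](Cc2ccccc2)[C@H]1Cc1ccccc1` gives 77000 nM 
Compound 2 `O=C1OC[C@H](Cc2ccccc2)[C@H]1Cc1ccccc1F` gives 72000 nM 
Compound 3 `COc1cccc(C[C@H]2C(=O)OC[C@@H]2Cc2ccccc2)c1` gives 66000 nM 

Compound 3 stands level with compound 1 and compound 2, since all three values lie within the scatter of one another and no order can be drawn among them. Compound 4 `Cc1cccc(C[C@H]2C(=O)OC[C@@H]2Cc2ccccc2)c1` differs from compound 3 in one place, with methyl in place of methoxy on an aromatic carbon, meta to a large group (methyl in place of methoxy on an aromatic carbon). Among the measured compounds shown here, two measured steps bear on this change. Bringing in methoxy gave a 1.2-fold lower number from compound 1 to compound 3 (0.07 log units; within the scatter) and stayed within the scatter. Fluoro in place of hydrogen on an aromatic carbon gave a 1.1-fold lower number from compound 1 to compound 2 (0.03 log units; within the scatter) and also stayed within the scatter. For the measured compounds named here, no measured compound carries methyl and no measured step removes methoxy, so the comparison is indirect. Starting from compound 3 at 66000 nM and its small step from compound 1, no shift beyond the scatter is expected in this assay and no direction is favoured. The expected step is a 1.0-fold lower number from compound 3 to compound 4 (0.01 log units; within the scatter) and it would stay within the scatter. For compound 4 the estimated value is 65000 nM with an expected range from 35000 nM to 110000 nM for the coming measurement.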

Compound 4, half-maximal effective concentration: 53000 nM
Compound 4: the middle estimate sits 1.2-fold (0.09 log units) above what was measured; measured number inside the range.
By their numbers in this assay, from the lowest: compounds 4, 3, 2 and 1 (each within the scatter of the next).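

In this assay, methyl in place of methoxy on an aromatic carbon, meta to a large group, gives a step that stays within the scatter (a 1.2-fold lower number from compound 3 to compound 4 (0.10 log units; within the scatter)), and methyl in place of hydrogen on that carbon does the same (a 1.5-fold lower number from compound 1 to compound 4 (0.16 log units; within the scatter)). This aromatic carbon has now carried hydrogen, methoxy and methyl with no step beyond the scatter, and 3-methylphenyl in place of 2-fluorophenyl on the saturated chain carbon also stays within it (a 1.4-fold lower number from compound 2 to compound 4 (0.13 log units; within the scatter)), so the four compounds stand level, with no order among them. No measurement gives a reason for this flat result.

On these data alone, whether an amine or a carboxylic acid on this aromatic carbon, or a longer chain in place of methyl, would move the number beyond the scatter remains open. The compounds shown also leave open whether a change to the shared core, rather than to this aromatic carbon, would give a step beyond the scatter in this cell assay.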